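The compounds below may be only part of what the source reports. "The series", "measured", "known", "first", "only" and "open" are said of these compounds alone.

Measured so far in a functional assay on the whole organism for antagonist activity, with Mus musculus as the target; a lower number here means that less compound is needed, a higher number that more compound is needed for the effect:
compound 1 `CCOC(=O)N(C)CC#CCn1ccnc1`: 97 mg/kg
compound 2 `CCOC(=O)N(C)CC#CCn1cncc1C`: 66 mg/kg
compound 3 `CCOC(=O)N(C)C(C)C#CCn1cncc1C`: 17.3 mg/kg

Compound 2 sits in the upper pair of these three numbers. The two measured steps are a 1.5-fold lower number from compound 1 to compound 2 (0.17 log units; within the scatter) and a 3.8-fold lower number from compound 2 to compound 3 (0.58 log units; beyond the scatter). The first, methyl in place of hydrogen on an aromatic carbon, stays within the scatter. The second, methyl in place of hydrogen on a saturated chain carbon, goes beyond it, though only modestly.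

Compound 4 `Cc1cncn1CC#CCN(C)C(=O)N(C)C` keeps the rest of compound 2 and changes one group: dimethylamino in place of ethoxy on a carbonyl carbon. This takes ethoxycarbonyl to dimethylcarbamoyl. Neither measured step touches this carbonyl carbon, so the series gives no direct reading of the change. The steps bear on it only as a guide to size in this assay, where the largest seen so far is a 3.8-fold lower number from compound 2 to compound 3 (0.58 log units; beyond the scatter), at a different place. With no evidence for a direction, no shift beyond the scatter is expected, although the uncertainty is wide in both directions. The expected step is a 1.1-fold higher number from compound 2 to compound 4 (0.03 log units; within the scatter). For compound 4 the estimated value is 70 mg/kg, with an expected range of 25 mg/kg to 200 mg/kg.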

Compound 4, dose for half-maximal effect: 11.8 mg/kg
Beside the measured number, compound 4's estimate is 5.9-fold (0.77 log units) above it; measured number outside the range, below it.
By their numbers in this assay, from the lowest: compounds 4 and 3 (each within the scatter of the next); then compounds 2 and 1 (each within the scatter of the next).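

Going by these compounds alone, the carbonyl carbon, untouched by the earlier steps, proves to be a place where a single change moves the number in this assay: dimethylamino in place of ethoxy gives a 5.6-fold lower number from compound 2 to compound 4 (0.75 log units; beyond the scatter), a modest step but one beyond the scatter. The exchange leaves the count of heavy atoms in the group unchanged and no ring is involved; what differs is nitrogen for oxygen, with the computed hydrogen-bond acceptors of the group going from 1 to 0, so ethoxycarbonyl and dimethylcarbamoyl are not interchangeable in this series. Nothing available on this step accounts for the lower number, and no measurement of any property of the two groups stands with it.

From the compounds shown here alone, whether the effect belongs to the nitrogen itself or to its two methyl groups remains open, and methylamino, diethylamino or pyrrolidine on the same carbonyl carbon would be needed to separate these readings. The compounds shown also leave open whether dimethylamino and the methyl on the saturated chain carbon would add up in one molecule, since no pair here tests the two changes together.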